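Swapping a cyclohexene for a fluorinated phenyl ring

The compounds below may be only part of what the source reports. "The series", "measured", "known", "first", "only" and "open" are said of these compounds alone.

Of the compounds shown here, three sharing one core have been tested in a functional assay for agonist activity at G protein-coupled receptor 88 (Homo sapiens), read by HTRF and cAMP accumulation; a lower number here means that less compound is needed, a higher number that more compound is needed for the effect. Compound 1 `CC(C)C[C@H](N)CN(C(=O)[C@@H]1C[C@H]1c1ccccc1)c1ccc(-c2ccccc2)cc1`, which carries a phenyl group, gives 880 nM. Compound 2 `CC(C)C[C@H](N)CN(C(=O)[C@@H]1C[C@H]1c1ccccc1)c1ccc(C2=CCCCCC2)cc1`, with a cyclohept-1-en-1-yl group in that place, gives 2100 nM. Compound 3 `CC(C)C[C@H](N)CN(C(=O)[C@@H]1C[C@H]1c1ccccc1)c1ccc(C2=CCCCC2)cc1`, with a cyclohex-1-en-1-yl group there, gives 1200 nM. Compound 3 sits close to both others: the step of a 1.4-fold higher number from compound 1 to compound 3 (0.13 log units; within the scatter) and the step of a 1.8-fold lower number from compound 2 to compound 3 (0.24 log units; within the scatter) each lie within the usual scatter, while a 2.4-fold higher number from compound 1 to compound 2 (0.38 log units; beyond the scatter) is a modest change beyond it.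

Compound 4 `CC(C)C[C@H](N)CN(C(=O)[C@@H]1C[C@H]1c1ccccc1)c1ccc(-c2ccc(F)cc2)cc1` differs from compound 3 by one change: 4-fluorophenyl in place of cyclohex-1-en-1-yl on an aromatic carbon. The steps from compound 1 to compound 3 and from compound 2 to compound 3 bear on this, since compound 1 already shows that an aromatic ring in this place gives a number close to that of the cyclohexene. Among the compounds with values here, no measured compound carries a fluorine, so its effect is unknown here. Compound 4 is therefore expected to stay near compound 1, giving an estimated step of a 1.5-fold lower number from compound 3 to compound 4 (0.18 log units; within the scatter), within the scatter. The estimate for compound 4 in this assay is 800 nM, with a range from 350 nM to 1800 nM.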

Compound 4, half-maximal effective concentration: 900 nM
Estimate against measurement, compound 4: 1.1-fold (0.05 log units) below; measured number inside the range.
By their numbers in this assay, from the lowest: compounds 1, 4, 3 and 2 (each within the scatter of the next, the first and the last beyond it).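

In this assay the new information concerns the fluorine: 4-fluorophenyl in place of phenyl on compound 1 leaves the number within the scatter (a 1.0-fold higher number from compound 1 to compound 4 (0.01 log units; within the scatter)). The fluorinated ring also lies within the scatter of the cyclohex-1-en-1-yl group (a 1.3-fold lower number from compound 3 to compound 4 (0.12 log units; within the scatter)), while the cyclohept-1-en-1-yl group now stands modestly apart from a second aromatic ring (a 2.3-fold lower number from compound 2 to compound 4 (0.37 log units; beyond the scatter)), although compound 2 remains within the scatter of compound 3. Nothing measured here explains these results or says what the fluorine does at this position.

Every group shown at this place is a ring of carbon only, so a ring containing nitrogen, such as pyridine, remains open. Also open, going by these compounds, is whether an amine, a carboxylic acid or a longer chain in place of the fluorine would move the number beyond the scatter.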